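This account rests on a few compounds, and the source may have more. Where it says the series, first, only, none or still open, it means among the compounds named here.

Compound 2 `C[C@@H](Cn1c(=O)[nH]/c(=N\c2ccc(Oc3cncc(F)c3)cc2)n(Cc2ccc(Cl)cc2)c1=O)C(=O)O` is the starting point. In an ADME assay on the whole organism (plasma, Rattus norvegicus) for protein binding, using cassette dosing, at a dose of 1 mg/kg (on this read-out higher numbers stand for a larger free fraction and lower numbers for a smaller free fraction), compound 2 gives 0.02. Among the three measured compounds its number stands at the top, yet neither of the other two is separated from it beyond the usual scatter: compound 1 `C[C@@H](Cn1c(=O)[nH]/c(=N\c2ccc(Oc3ccccn3)cc2)n(Cc2ccc(Cl)cc2)c1=O)C(=O)O` gives 0.01 in this assay, and compound 3 `Cc1ccc(Cn2c(=O)n(CC(C)(C)C(=O)O)c(=O)[nH]/c2=N\c2ccc(OC(C)C)c(Cl)c2)cc1` gives 0.01. Within the data shown here, the one single-point step that has been measured, a 2.0-fold higher number from compound 1 to compound 2 (0.30 log units; within the scatter), lies within the scatter, so within this set the read-out has so far not moved beyond noise.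

Compound 4 `C[C@@H](Cn1c(=O)[nH]/c(=N\c2ccc(OC3CCC3)cc2)n(Cc2ccc(Cl)cc2)c1=O)C(=O)O` differs from compound 2 in one place: cyclobutyl in place of 5-fluoropyridin-3-yl on an oxygen on an aromatic ring. Among the measured compounds shown here, no measured step exchanges an aromatic ring for a saturated ring on this oxygen, so nothing in the data speaks directly to this change; the only available step, from compound 1 to compound 2, varied the aromatic ring itself and stayed within the scatter. All three measured numbers sit close together at the low end of the read-out.

On that basis the step of a 1.3-fold lower number from compound 2 to compound 4 (0.12 log units; within the scatter) is expected to remain within the scatter. Compound 4 is therefore estimated at 0.015 in this assay, with a range from 0.006 to 0.04.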

Compound 4, unbound fraction: 0.015
Estimate against measurement, compound 4: no gap at the digits printed, and the stated range covers the measured number.
By their numbers in this assay, from the lowest: compounds 1, 3, 4 and 2 (each within the scatter of the next).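

On the oxygen on an aromatic ring, the exchange now reaches beyond aromatic rings: in this assay, cyclobutyl in place of 5-fluoropyridin-3-yl gives a 1.3-fold lower number from compound 2 to compound 4 (0.12 log units; within the scatter), and cyclobutyl in place of pyridin-2-yl gives a 1.5-fold higher number from compound 1 to compound 4 (0.18 log units; within the scatter). The earlier step had only exchanged one aromatic ring for another at this place, whereas here a four-membered non-aromatic ring of carbon only, with 4 heavy atoms against 7 and 0 hydrogen-bond acceptors against 1, still leaves the read-out within the scatter of both compounds that carry an aromatic ring on this oxygen. Nothing available here explains why these exchanges leave the free fraction within the scatter.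

Going by these compounds, it remains open whether any group at this place can move the read-out beyond the scatter, for example an amine, a carboxylic acid or a longer chain on the oxygen. Also open, on these data alone, is whether the same insensitivity holds at other parts of the molecule, since compound 3 differs from the others in more than one place and cannot be compared with them directly.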